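A few compounds are considered here, and "the series" means these few. Any claim that something is new, unique, unknown or untested is made for them only; others in the source may bear on it.

Of the compounds shown here, two sharing one core have been tested in a functional assay on the whole organism (strain albino) for inhibition, with Rattus norvegicus as the target, read by paw edema, with a stated time of 1 h, at a dose of 100 mg/kg by the oral route; on this read-out higher numbers stand for more inhibition at the one dose given (going by the name of the read-out) and lower numbers for less inhibition. Compound 1 `N#Cc1c(Cl)nc(SCC(=O)Nn2c(COc3ccc(Cl)cc3Cl)nc3ccccc3c2=O)nc1-c1ccc(O)cc1` gives 72.7% in this assay. Compound 2 `N#Cc1c(Nc2ccccc2)nc(SCC(=O)Nn2c(COc3ccc(Cl)cc3Cl)nc3ccccc3c2=O)nc1-c1ccc(Cl)cc1` gives 43.6% in this assay, the lowest of the two numbers; the nearest number, that of compound 1, lies higher by an amount beyond the usual scatter. Compound 3 `N#Cc1c(Nc2ccccc2)nc(SCC(=O)Nn2c(COc3ccc(Cl)cc3Cl)nc3ccccc3c2=O)nc1-c1ccc(O)cc1` has not yet been measured. Going by the values given here, it is built from compound 2 by a single change: hydroxy in place of chloro on an aromatic carbon Everything else in compound 3 is as in compound 2, while compound 1 differs from compound 3 at another part of the shared core, so no measured pair shows this change alone and its size can only be estimated. A rise is expected, as a step of a number 14.4 percentage points higher from compound 2 to compound 3 (beyond the scatter), since compound 1 gives 72.7% and carries the same hydroxy, although the second difference to compound 1 leaves this uncertain. Compound 3 is therefore expected to give about 58% in this assay, within a range from 42% to 74%.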

Compound 3, a percentage reported as inhibition, in the whole organism at one dose (the size of the read-out at that dose, not a potency): 90.9%
Compound 3: middle estimate off by 32.9 percentage points, on the low side; measured number above the stated range.
By their numbers in this assay, from the lowest: compound 2; then compound 1; then compound 3.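

In this assay, hydroxy in place of chloro on the six-membered aromatic ring, the change from 4-chlorophenyl to 4-hydroxyphenyl, now has a measured size on its own (a number 47.3 percentage points higher from compound 2 to compound 3 (beyond the scatter)), and it is large, so this position strongly affects the read-out when anilino sits elsewhere on the shared core. Going by these compounds alone, with the 4-hydroxyphenyl held constant, a second position can also be read for the first time: anilino in place of chloro on an aromatic carbon gives a modest gain (a number 18.2 percentage points higher from compound 1 to compound 3 (beyond the scatter)), so the larger of these two steps belongs to the hydroxy change. No measurement here explains why either change raises the inhibition.

On these data alone, the hydroxy step is known only with anilino on the core, so its size with chloro there, as in the core of compound 1, remains unknown. Within the data shown here, it is also unclear whether hydroxy is the only group that gives this rise at this position, since methoxy, an amine or a carboxylic acid in the same place could give a different result, and all these numbers come from one dose, so they do not measure potency.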